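This account rests on a few compounds, and the source may have more. Where it says the series, first, only, none or still open, it means among the compounds named here.

Measured so far:
compound 1 `CCCc1nn(C)c2c(NC(C)C)nc(-c3cc(OC)c(OC)c(OC)c3)nc12`: 10800 nM
compound 2 `CCCc1nn(C)c2c(NCC(C)C)nc(/C=C/c3ccccc3)nc12`: 22100 nM

In a functional assay on RAW264.7 cells (Mus musculus) for inhibition, read by Griess assay, with stated times of 1 h and 24 h (on this read-out lower numbers stand for stronger inhibition and higher numbers for weaker inhibition), compound 1 stands at the lower of the two numbers shown; the number for compound 2 lies beyond the scatter above it. Compound 3 `CCCc1nn(C)c2c(Nc3ccc(C(=O)O)cc3)nc(-c3cc(OC)c(OC)c(OC)c3)nc12` is not yet measured in this assay. Its change from compound 1: 4-carboxyphenyl in place of isopropyl on a nitrogen on an aromatic ring. Among the measured compounds shown here, no measured pair shows a comparable change, so the size of the step is open. The step of a 1.2-fold lower number from compound 1 to compound 3 (0.08 log units; within the scatter) is expected to lie within the scatter, with a wide range of uncertainty. The estimate for compound 3 is 9000 nM, range 2500 nM to 35000 nM.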

Compound 3, half-maximal inhibitory concentration: 15800 nM
Compound 3: middle estimate off by 1.8-fold (0.24 log units), on the low side; low and high end bracket the measured number.
By their numbers in this assay, from the lowest: compounds 1, 3 and 2 (each within the scatter of the next, the first and the last beyond it).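

In this assay, replacing isopropyl with 4-carboxyphenyl on the nitrogen on an aromatic ring gives a 1.5-fold higher number from compound 1 to compound 3 (0.17 log units; within the scatter). This position therefore accepts a six-membered aromatic ring bearing a carboxylic acid in place of a small branched chain, with no step beyond the scatter. Nothing available explains why the two groups read alike.

From the compounds shown here alone, whether the ring or the carboxylic acid governs this reading stays open; a plain phenyl or a methyl ester on the same nitrogen would separate the two. Also open, going by these compounds, is whether a longer alkyl chain here would move the number beyond the scatter.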